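From propyl to butyl: compound 1 and compound 4

The source may report more compounds than this note shows. Statements on the series, on what has been measured and on what is new or still open speak of the compounds shown alone.

Measured in an ADME assay on MCF7-DOX cells (Homo sapiens) for cytotoxicity, read by MTT assay, with a stated time of 48 h; on this read-out higher numbers stand for weaker inhibition and lower numbers for stronger inhibition:
- compound 1 `CCCc1c(OC)cc(OC)c(C(=O)/C=C/c2cccc(N3CCNCC3)c2)c1O` gives > 100000 nM (a limit, not a number)
- compound 2 `COc1cc(O)c(C(=O)/C=C/c2ccc(N3CCN(C(=O)OC(C)(C)C)CC3)cc2)c(OC)c1` gives 47300 nM
- compound 3 `COc1ccc(/C=C/C(=O)c2c(OC)cc(OC)c(CC=C(C)C)c2O)cc1` gives 46900 nM

Compound 1 stands at the limit of > 100000 nM in this assay, at which 1 of the 3 values shown sits, and so carries a limit rather than a number. Compound 2 and compound 3 give values within the scatter of each other, and neither differs from compound 1 in one place alone.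

Compound 4 `CCCCc1c(OC)cc(OC)c(C(=O)/C=C/c2cccc(N3CCNCC3)c2)c1O` has not yet been measured. It departs from compound 1 by a single change (methyl in place of hydrogen on a saturated chain carbon, three bonds along the chain from an aromatic carbon): methyl in place of hydrogen on a saturated chain carbon, three bonds along the chain from an aromatic carbon, which turns propyl into butyl.

No measured single change in this assay gives a guide to the size of this step. Only a small shift toward stronger inhibition is expected, perhaps none beyond the scatter, and the estimated step is modest (an at least 1.2-fold lower number from compound 1 to compound 4 (0.09 log units; that floor lies within the scatter)). Compound 4 may also turn out to give only a limit. The expected value for compound 4 is about 80000 nM (estimated range 35000 nM to 150000 nM).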

Compound 4, half-maximal inhibitory concentration: > 100000 nM
Compound 4: no number, only a limit (the forecaster's own chance of this, stated with the estimate: 45%); at least 1.2-fold (0.09 log units) between middle value and limit.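

Compound 4, like compound 1, carries only a limit and not a number in this assay, so no step from compound 1 to compound 4 can be read: the limit of > 100000 nM in this assay, at which 2 of the 4 values shown sit.

The compounds shown leave open whether turning propyl into butyl changes inhibition at all, and how far past that limit compound 1 and compound 4 each lie.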